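A Chloro Substituent Carried from One Core to Another

This account rests on a few compounds, and the source may have more. Where it says the series, first, only, none or still open, it means among the compounds named here.

The study examines cytotoxicity across two related cores. Compound 1 `COc1ccc(OC)c(-c2cc(-c3ccccc3)nn2-c2ccc(S(=O)(=O)NC(C)=O)cc2)c1` is the reference on the first core; in a functional assay on cells (Cancer cell lines, Homo sapiens) for cytotoxicity, read by sulforhodamine B assay, with a stated time of 48 h (on this read-out higher numbers stand for weaker inhibition of growth and lower numbers for stronger inhibition of growth), compound 1 gives 3740 nM. Compound 2 `COc1ccc(OC)c(-c2cc(-c3ccc(Cl)cc3)nn2-c2ccc(S(=O)(=O)NC(C)=O)cc2)c1` differs from compound 1 by chloro in place of hydrogen on an aromatic carbon, and in this assay compound 2 gives 8180 nM. The measured step is a 2.2-fold higher number from compound 1 to compound 2 (0.34 log units; beyond the scatter).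

Compound 3 `NS(=O)(=O)c1ccc(-n2nc(-c3ccccc3)cc2-c2cc(O)ccc2O)cc1` sits on a second core; the difference between the two cores is not broken down here. In this assay compound 3 gives 75700 nM, the highest of the three measured numbers, with its steps to compound 2 and to compound 1 both beyond the scatter.

Compound 4 `NS(=O)(=O)c1ccc(-n2nc(-c3ccc(Cl)cc3)cc2-c2cc(O)ccc2O)cc1` has not yet been measured. It differs from compound 3 by chloro in place of hydrogen on an aromatic carbon, and the place of the change is described in the same words as for the change from compound 1 to compound 2, so the same change is made here on a second core. Among the compounds with values here, the only guide to its size is the earlier step, a 2.2-fold higher number from compound 1 to compound 2 (0.34 log units; beyond the scatter), which was modest and beyond the scatter. Resting on that one precedent, the step for compound 4 is expected to be a 2.0-fold higher number from compound 3 to compound 4 (0.30 log units; within the scatter). Compound 4 is therefore expected to give about 150000 nM in this assay. The expected range for compound 4 runs from 60000 nM to 400000 nM. A number this high may fall outside what the assay reports, in which case only a limit would be given.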

Compound 4, concentration for 50% growth inhibition: 15100 nM
Compound 4: the middle estimate sits 9.9-fold (1.00 log units) above what was measured; the whole stated range lies above it.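

On the second core, chloro in place of hydrogen on an aromatic carbon gives a 5.0-fold lower number from compound 3 to compound 4 (0.70 log units; beyond the scatter) in this assay, so the change from phenyl to 4-chlorophenyl weakens growth inhibition on the first core but strengthens it on the second. Set side by side, the two steps run in opposite directions, and the gap between them is larger than repeated measurements would explain, so the step measured on one core does not carry over to the other in this series: the same change on two cores in this assay, a 2.2-fold higher number (0.34 log units; beyond the scatter) from compound 1 to compound 2 and a 5.0-fold lower number (0.70 log units; beyond the scatter) from compound 3 to compound 4, 11-fold (1.04 log units) apart, beyond the scatter of two such steps This rests on a single pair on each core, and it does not show which feature of the cores sets the direction of the step, nor does it establish a rule for any compound beyond these four.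

The compounds shown leave open whether bromo, an amine or a carboxylic acid on the same aromatic carbon would follow the first core, the second core or neither. They also leave open what the chloro step would be on a core that carries only part of the difference between the two cores, which would be needed to trace the reversal to one place.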